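Methylsulfanyl in place of aminoamino, second instance

The source may hold more compounds than are shown below. What is called first, only, known or untested is meant among the compounds shown, and "the series" means these compounds.

The series is a set of four compounds on one shared core, varied at the aromatic carbon between two ring nitrogen atoms and at the aryl group attached to the core. Compound 3 `Cn1c(NN)nc(-c2ccco2)c(C#N)c1=O` gives 65 ug/mL in a functional assay, with a stated time of 150 min; a lower number here means a stronger inhibitor, a higher number a weaker inhibitor. Compound 1 `CSc1nc(-c2ccco2)c(C#N)c(=O)n1C` gives 108 ug/mL in this assay. The difference between them is methylsulfanyl in place of aminoamino on an aromatic carbon, and the step it made is a 1.7-fold higher number from compound 3 to compound 1 (0.22 log units; within the scatter). Compound 2 `Cn1c(NN)nc(-c2cccc(O)c2O)c(C#N)c1=O` gives 44 ug/mL in this assay; its number and that of compound 3 lie within the scatter of each other, while the number for compound 1 stands beyond the scatter above it. The difference between the cores of compound 2 and compound 3 is not broken down here.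

Compound 4 `CSc1nc(-c2cccc(O)c2O)c(C#N)c(=O)n1C` has not yet been measured. Its difference from compound 2 is methylsulfanyl in place of aminoamino on an aromatic carbon. The surroundings of the place are not identical: in compound 3 the carbon is meta to a furan-2-yl group (5 heavy atoms), in compound 2 it is meta to a group of 8 heavy atoms, so this is the same kind of change, not the same change. The step expected in this assay is a 1.6-fold higher number from compound 2 to compound 4 (0.20 log units; within the scatter). This expectation rests on the measured step of a 1.7-fold higher number from compound 3 to compound 1 (0.22 log units; within the scatter), taken as a guide for the same kind of change. Compound 4 is therefore estimated at 70 ug/mL, with a range from 40 ug/mL to 130 ug/mL.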

Compound 4, half-maximal inhibitory concentration: 53 ug/mL
Compound 4: middle estimate off by 1.3-fold (0.12 log units), on the high side, within the range that was stated.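

In this assay, methylsulfanyl in place of aminoamino on the core of compound 2 gives a 1.2-fold higher number from compound 2 to compound 4 (0.08 log units; within the scatter). Set beside the earlier instance, the two steps cannot be told apart, so in these two pairs the change reads the same whether the furan-2-yl group or the group of 8 heavy atoms is on the core: the same change on two cores in this assay, a 1.7-fold higher number (0.22 log units; within the scatter) from compound 3 to compound 1 and a 1.2-fold higher number (0.08 log units; within the scatter) from compound 2 to compound 4, 1.4-fold (0.14 log units) apart, within the scatter of two such steps

Going by these compounds alone, this agreement shows only that the step stayed within the scatter on both cores; it does not establish an effect of the change in either direction, nor does it show that the change would carry to a third core or to another assay.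

Open, going by these compounds, is whether other groups on the aromatic carbon between two ring nitrogen atoms, such as a simple amine, a carboxylic acid or a longer alkylsulfanyl chain, would also stay within the scatter of aminoamino and methylsulfanyl. Also open, on these data alone, is how the step would read with a plain phenyl group in place of the furan-2-yl group, which would give a further core for testing whether the change carries.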